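A few compounds are considered here, and "the series" means these few. Any claim that something is new, unique, unknown or untested is made for them only; others in the source may bear on it.

Working notes on the series. In an ADME assay on Vero cells (Chlorocebus sabaeus) for cytotoxicity, read by WST assay, tested at 100 ug/mL (on this read-out lower numbers stand for a stronger effect and higher numbers for a weaker effect at the one concentration tested), compound 2 `COC(=O)[C@@H]1COC(/C=C/c2ccc(OC)cc2)=N1` gives 20.9%. Going by the values given here, the only other number belongs to compound 1 `COC(=O)[C@@H]1COC(/C=C/c2ccc(F)cc2)=N1`, which in this assay gives 18.6%; the step of a number 2.3 percentage points higher from compound 1 to compound 2 (within the scatter) lies within the scatter, so the two numbers are not separated. Compound 3 `COC(=O)[C@@H]1COC(/C=C/c2ccc(C)cc2)=N1` differs from compound 2 by methyl in place of methoxy on an aromatic carbon. Among the compounds with values here, no measured step removes a methoxy or introduces a methyl; the one step available, a number 2.3 percentage points higher from compound 1 to compound 2 (within the scatter), exchanged groups at the same place and stayed within the scatter, so no step beyond the scatter in this assay is expected here. Compound 3 is estimated at 21%, with a range from 11% to 31%. This amounts to an expected step of a number 0.1 percentage points higher from compound 2 to compound 3 (within the scatter).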

Compound 3, a percentage reported as activity, at one concentration (the size of the read-out at that concentration, not a potency): 17%
Compound 3: middle estimate off by 4 percentage points, on the high side; low and high end bracket the measured number.
By their numbers in this assay, from the lowest: compounds 3, 1 and 2 (each within the scatter of the next).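

With methyl on the aromatic carbon para to a large group, a third group joins methoxy and fluoro at this position, and in this assay both new exchanges stay within the scatter: a number 3.9 percentage points lower from compound 2 to compound 3 (within the scatter), and a number 1.6 percentage points lower from compound 1 to compound 3 (within the scatter). Across compounds 1, 2 and 3, this position therefore shows no separation among these three groups. No measurement shown bears on any cause for this. Open, from the compounds shown here alone, is whether an amine, a carboxylic acid or a longer chain at this position would give a step beyond the scatter. Also open, going by these compounds, is whether changes elsewhere on the shared core would do so.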